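The compounds below may be only part of what the source reports. "The series", "measured", "known", "first", "only" and "open" are said of these compounds alone.

Compound 1 `CC[C@@H](CCn1cncn1)c1ccccc1` and compound 2 `CC[C@@H](CCn1cncn1)c1ccc(Cl)cc1` share one core; compound 2 carries chloro in place of hydrogen on an aromatic carbon. In an ADME assay on RD cells (Homo sapiens) for cytotoxicity, read by MTT assay, with a stated time of 3 days (on this read-out lower numbers stand for higher toxicity in this test and higher numbers for lower toxicity in this test), compound 1 gives 91.2 ug/mL, and compound 2 gives 55.3 ug/mL, which amounts to a 1.6-fold lower number from compound 1 to compound 2 (0.22 log units; within the scatter). Compound 3 `CCCC[C@H](CCn1cncn1)c1ccccc1` rests on a core whose difference from the core of compound 1 is not broken down here. In this assay compound 3 gives 48.3 ug/mL, its two values sitting close to the pair just described. Compound 4 `CCCC[C@H](CCn1cncn1)c1ccc(Cl)cc1` differs from compound 3 by chloro in place of hydrogen on an aromatic carbon, the same kind of change, described in the same words, as that from compound 1 to compound 2. The expected step is a 1.4-fold lower number from compound 3 to compound 4 (0.15 log units; within the scatter), because the earlier change gave a 1.6-fold lower number from compound 1 to compound 2 (0.22 log units; within the scatter). In this assay compound 4 is therefore estimated at 34 ug/mL, with a likely range from 18 ug/mL to 65 ug/mL.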

Compound 4, half-maximal cytotoxic concentration: 20.3 ug/mL
Compound 4: the middle estimate sits 1.7-fold (0.22 log units) above what was measured; measured number inside the range.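

In this assay chloro in place of hydrogen on an aromatic carbon gives a 2.4-fold lower number from compound 3 to compound 4 (0.38 log units; beyond the scatter) and so, as on the core of compound 1, moves the number toward higher toxicity in this test. The change runs the same way on both cores, and the two step sizes cannot be told apart: the same change on two cores in this assay, a 1.6-fold lower number (0.22 log units; within the scatter) from compound 1 to compound 2 and a 2.4-fold lower number (0.38 log units; beyond the scatter) from compound 3 to compound 4, 1.4-fold (0.16 log units) apart, within the scatter of two such steps

Among these compounds, this rests on only two pairs, so it does not show that the step would hold on any other core, nor why the chloro acts as it does.

The compounds shown leave open whether fluoro, methoxy or a nitrile in that place would move the number the same way. They also leave open whether the step would persist on a core with a longer chain.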